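This account rests on a few compounds, and the source may have more. Where it says the series, first, only, none or still open, it means among the compounds named here.

Compound 3 `Cc1ccccc1C(=O)Nc1cccc(-c2oc3cc(-c4ccc(F)cc4)ccc3c(=O)c2O)c1` in a functional assay on MDA-MB-231 cells (Homo sapiens) for antiproliferative activity, read by CCK-8 assay, with a stated time of 72 h (a higher number here means a weaker inhibitor, a lower number a stronger inhibitor), gives 4910 nM, the second highest of the three numbers in hand. Compound 1 `Cc1ccc(C(=O)Nc2cccc(-c3oc4cc(-c5ccc(F)cc5)ccc4c(=O)c3O)c2)cc1` gives 4350 nM in this assay, and the two sit within the scatter of each other: a 1.1-fold higher number from compound 1 to compound 3 (0.05 log units; within the scatter). Compound 2 `O=C(Nc1cccc(-c2oc3cc(-c4ccc(F)cc4)ccc3c(=O)c2O)c1)c1ccc(Cl)cc1` gives 12800 nM, and both of its steps lie beyond the scatter, a 2.9-fold higher number from compound 1 to compound 2 (0.47 log units; beyond the scatter) and a 2.6-fold lower number from compound 2 to compound 3 (0.42 log units; beyond the scatter). Taken together, the 4-methylphenyl and 2-methylphenyl amides read alike, while the 4-chlorophenyl amide reads weaker.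

Compound 4 `O=C(Nc1cccc(-c2oc3cc(-c4ccc(F)cc4)ccc3c(=O)c2O)c1)c1cccc(F)c1` is the next member: 3-fluorophenyl in place of 2-methylphenyl on a carbonyl carbon. Going by the values given here, no measured step swaps a methyl for a fluorine, nor a 2-substituted ring for a 3-substituted one, so the bearing of the measured steps is indirect. The step to the halogenated ring on the carbonyl carbon, a 2.9-fold higher number from compound 1 to compound 2 (0.47 log units; beyond the scatter), was a modest loss, and moving the methyl around that ring, a 1.1-fold higher number from compound 1 to compound 3 (0.05 log units; within the scatter), gave nothing beyond the scatter. A halogen on this ring is therefore expected to read somewhat weaker than compound 3, smaller in size than seen with compound 2, or not beyond the scatter at all. Compound 4 is thus expected at 7000 nM, between 3000 nM and 16000 nM, which corresponds to an expected step of a 1.4-fold higher number from compound 3 to compound 4 (0.15 log units; within the scatter).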

Compound 4, half-maximal inhibitory concentration: 2510 nM
Compound 4: the middle estimate sits 2.8-fold (0.45 log units) above what was measured; measured number below the stated range.
By their numbers in this assay, from the lowest: compounds 4, 1 and 3 (each within the scatter of the next); then compound 2.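

In this assay, a halogen on the ring attached to the carbonyl carbon does not by itself go with the weaker reading: the 3-fluorophenyl amide stays within the scatter of both methylphenyl amides (a 2.0-fold lower number from compound 3 to compound 4 (0.29 log units; within the scatter); a 1.7-fold lower number from compound 1 to compound 4 (0.24 log units; within the scatter)). Compound 2 is now the only one of the four set apart, with a gap beyond the scatter to the new member (a 5.1-fold lower number from compound 2 to compound 4 (0.71 log units; beyond the scatter)), and compound 4 goes against any reading of the earlier data as a general halogen penalty, though this step changes both the halogen and its place on the ring. Nothing available explains the gap between these two halogenated amides.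

The compounds shown leave open whether the weaker reading of compound 2 follows the chloro group or the 4-position, a question that 4-fluorophenyl and 3-chlorophenyl amides would separate. They also leave open how this position responds to a ring bearing an amine or a carboxylic acid, or to a saturated cyclohexyl group in place of the aromatic ring.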